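Compound 2 to compound 3: a fluoro isomer

The source may report more compounds than this note shows. Statements on the series, on what has been measured and on what is new or still open speak of the compounds shown alone.

In a physicochemical assay for solubility, in phosphate buffer, at pH 7.4 (on this read-out lower numbers stand for lower solubility and higher numbers for higher solubility), compound 1 (`C=CC(=O)Nc1cc(Nc2nccc(-c3cn(C)c4ccccc34)n2)c(OC)cc1N(C)CC[N+](C)(C)[O-]`) gives > 10000 ug/mL, which is a limit and not a number. Compound 2 (`C=CC(=O)Nc1cc(Nc2nccc(-c3cn(C)c4ccc(F)cc34)n2)c(OC)cc1N(C)CCN(C)C`) gives < 100 ug/mL, also a limit and not a number. Compound 2 therefore sits at the low end of the two values shown, without an exact figure.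

Compound 3 (`C=CC(=O)Nc1cc(Nc2nccc(-c3cn(C)c4c(F)cccc34)n2)c(OC)cc1N(C)CCN(C)C`) carries 7-fluoro-1-methyl-1H-indol-3-yl in place of 5-fluoro-1-methyl-1H-indol-3-yl on an aromatic carbon. The two have the same atoms, joined differently. Within the data shown here, no measured pair shows this change. The expectation therefore rests on compound 2 and its limit of < 100 ug/mL. The estimated size is a step that the limit leaves unreadable from compound 2 to compound 3, meaning no step beyond the scatter is expected in this assay, in either direction. For compound 3 the estimated value is 60 ug/mL, with an expected range of 15 ug/mL to 200 ug/mL.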

Compound 3, solubility: < 100 ug/mL
Compound 3 gave a limit, no number; the forecaster's own chance of this, stated with the estimate: 70%; the middle value is on the limit's open side.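

In this assay, compound 2 and compound 3 both give limits, not numbers, and no step can be read between them. From the compounds shown here alone, whether 7-fluoro-1-methyl-1H-indol-3-yl and 5-fluoro-1-methyl-1H-indol-3-yl differ on this read-out remains open.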